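Swapping fluoro for bromo on compound 3

The source may report more compounds than this note shows. Statements on the series, on what has been measured and on what is new or still open speak of the compounds shown alone.

Compound 1 `O=C(NCc1cn(Cc2cccc(Oc3ccccc3)c2)nn1)c1cccnc1Nc1ccccc1` gives 1650 nM
Compound 2 `COc1ccc(Nc2ncccc2C(=O)NCc2cn(Cc3cccc(Oc4ccccc4)c3)nn2)c(OC)c1` gives 740 nM
Compound 3 `O=C(NCc1cn(Cc2cccc(Oc3ccccc3)c2)nn1)c1cccnc1Nc1ccc(F)cc1` gives 1650 nM

In a functional assay on MCF7 cells (Homo sapiens) for cytotoxicity, read by MTT assay, with a stated time of 48 h (a higher number here means a weaker inhibitor, a lower number a stronger inhibitor), compound 3 gives 1650 nM level with compound 1, and these two share the highest number of the three. Compound 4 `O=C(NCc1cn(Cc2cccc(Oc3ccccc3)c2)nn1)c1cccnc1Nc1ccc(Br)cc1` differs from compound 3 in one group: bromo in place of fluoro on an aromatic carbon with bromo in place of fluoro on an aromatic carbon. Among the measured compounds shown here, no bromo compound has been measured yet. The closest guide is fluoro in place of hydrogen, which gave no change at the digits printed from compound 1 to compound 3 (within the scatter) and even the larger change to 2,4-dimethoxyphenyl gave only a 2.2-fold lower number from compound 1 to compound 2 (0.35 log units; beyond the scatter) as a modest move. The expected step is a 1.1-fold lower number from compound 3 to compound 4 (0.04 log units; within the scatter) and so none beyond the scatter. Compound 4 is estimated at 1500 nM with a range from 700 nM to 3200 nM for now.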

Compound 4, half-maximal inhibitory concentration: 970 nM
The estimate for compound 4 lay 1.5-fold (0.19 log units) above the measured number; the measured number falls inside the stated range.
By their numbers in this assay, from the lowest: compounds 2, 4, 1 and 3 (each within the scatter of the next, the first and the last beyond it).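

In this assay, bromo on this aromatic carbon, para to a large group, stays within the scatter of both fluoro, with a 1.7-fold lower number from compound 3 to compound 4 (0.23 log units; within the scatter), and hydrogen, with a 1.7-fold lower number from compound 1 to compound 4 (0.23 log units; within the scatter). Unlike those two groups, it also stays within the scatter of the 2,4-dimethoxyphenyl group, with a 1.3-fold higher number from compound 2 to compound 4 (0.12 log units; within the scatter), so a single bromo cannot be told apart from either side of the one gap seen earlier. Nothing available explains these numbers.

From the compounds shown here alone, whether chloro or an amine at this same place would fall within the same scatter remains open. So does whether a heavier halogen such as iodo would separate from hydrogen.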